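The source may hold more compounds than are shown below. What is called first, only, known or untested is meant among the compounds shown, and "the series" means these compounds.

In a functional assay on MCF7 cells (Homo sapiens) for inhibition, read by MTT assay (on this read-out higher numbers stand for weaker inhibition of growth and lower numbers for stronger inhibition of growth), compound 1 (`COc1cc2oc(-c3cccc(NC(=O)c4cccc(Br)c4)c3)cc(=O)c2c(OC)c1OC`) gives 6340 nM and compound 2 (`COc1cc2oc(-c3cccc(NC(=O)c4ccc(F)cc4)c3)cc(=O)c2c(OC)c1OC`) gives 14700 nM, the higher of the two numbers. Going by the values given here, the only measured step, a 2.3-fold higher number from compound 1 to compound 2 (0.37 log units; beyond the scatter), is modest and alters the group on the same carbonyl carbon. Compound 3 (`COc1ccc(C(=O)Nc2cccc(-c3cc(=O)c4c(OC)c(OC)c(OC)cc4o3)c2)cc1`) differs from compound 2 by methoxy in place of fluoro on an aromatic carbon, (methoxy in place of fluoro on an aromatic carbon). Among the compounds with values here, no measured step covers this exact exchange, so no step beyond the scatter is expected in this assay. The expected step is a 1.2-fold lower number from compound 2 to compound 3 (0.09 log units; within the scatter). For compound 3 the estimated value is 12000 nM, with an expected range of 5500 nM to 27000 nM.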

Compound 3, concentration for 50% growth inhibition: 6870 nM
The estimate for compound 3 lay 1.7-fold (0.24 log units) above the measured number; the range from low to high includes it.
By their numbers in this assay, from the lowest: compounds 1 and 3 (each within the scatter of the next); then compound 2.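

In this assay, the change on the aromatic carbon para to a large group gives a 2.1-fold lower number from compound 2 to compound 3 (0.33 log units; beyond the scatter) and shows that this position responds to an exchange of fluoro for methoxy. The step of a 1.1-fold higher number from compound 1 to compound 3 (0.03 log units; within the scatter) lies within the scatter, so the 4-methoxyphenyl group of compound 3 and the 3-bromophenyl group of compound 1 cannot be told apart, and compound 2 alone stands higher. Nothing at hand explains this difference. From the compounds shown here alone, whether an amine or a longer chain such as ethoxy at this place would match methoxy remains open.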